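Chloro on the phenyl of compound 1: a small step expected

This account rests on a few compounds, and the source may have more. Where it says the series, first, only, none or still open, it means among the compounds named here.

Compound 1 `c1ccc(-c2nc3sc(-c4ccccc4)cn3n2)cc1` was examined in a functional assay on PC-3 cells (Homo sapiens) for inhibition, read by sulforhodamine B assay, with a stated time of 48 h, tested at 10 uM (a higher number here means more inhibition of growth at the concentration tested, a lower number less inhibition of growth), where compound 1 gives 37%. For the measured compounds named here, only one other compound has been measured alongside it: compound 2 `COc1cc(-c2nc3sc(-c4ccccc4)cn3n2)cc(OC)c1OC`, which in this assay gives 53%. Compound 1 thus stands at the lower of the two numbers, and the gap to compound 2 lies beyond the usual scatter. Going by the values given here, no pair differing in a single place has been measured, so no step size is known from the data themselves.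

Compound 3 `Clc1ccc(-c2cn3nc(-c4ccccc4)nc3s2)cc1` differs from compound 1 in one place: chloro in place of hydrogen on an aromatic carbon. The rest of the shared core and the second phenyl stay as in compound 1.

Among the compounds with values here, with no measured step of this kind to draw on, the expectation for compound 3 rests on compound 1 alone, and only a small shift is expected, possibly none beyond the scatter; the step of a number 5 percentage points higher from compound 1 to compound 3 (within the scatter) is the estimated size. In this assay compound 3 is therefore expected to give about 42%, most likely between 25% and 60%.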

Compound 3, percent growth inhibition at one concentration: 31%
Compound 3: middle estimate off by 11 percentage points, on the high side; measured number inside the range.
By their numbers in this assay, from the lowest: compounds 3 and 1 (each within the scatter of the next); then compound 2.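

In this assay, the change from phenyl to 4-chlorophenyl gives a number 6 percentage points lower from compound 1 to compound 3 (within the scatter) as the first step measured at a single place in this small set. It shows that chloro in place of hydrogen on this aromatic carbon, para to a large group, leaves compound 3 within the scatter of compound 1, so this one added chlorine atom gives no readable shift in percent growth inhibition at the concentration tested. The data give no explanation for this result, and none of the measurements shown bears on it.

On these data alone, the result covers one substituent at one place, so it remains open whether an amine or a carboxylic acid on the same aromatic carbon would move the number beyond the scatter. As far as these compounds go, it also remains open whether chloro on another carbon of this ring, or on the second phenyl, would behave as it does here, and whether a longer chain at this place would be tolerated in the same way.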